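Working notes: from compound 3 to compound 4 in cytotoxicity

The source may hold more compounds than are shown below. What is called first, only, known or untested is meant among the compounds shown, and "the series" means these compounds.

Compound 1, `O=c1ncccn1SCCc1ccc(Nc2ncc(Cc3c(F)cccc3F)o2)cc1`, gives > 100000 nM in an ADME assay on MT2 cells (Homo sapiens) for cytotoxicity, read by MTT assay (a lower number here means that less compound is tolerated, a higher number that more compound is tolerated), which is a limit of the assay and not a number.
Compound 2, `N#Cc1ccc(Nc2ncc(Cc3c(F)cccc3F)o2)cc1`, gives 7400 nM in this assay.
Compound 3, `Fc1cccc(F)c1Cc1cnc(Nc2ccc(COc3ccncc3)cc2)o1`, gives > 100000 nM in this assay, again a limit of the assay.

Compound 3 therefore stands at the top of what the assay reports, alongside compound 1: the limit of > 100000 nM in this assay, at which 2 of the 3 values shown sit. The measured step of an at least 13-fold higher number from compound 2 to compound 3 (1.13 log units; beyond the scatter) is large and runs toward better tolerance, while a step that the two limits leave unreadable from compound 1 to compound 3 cannot be read because both ends are limits.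

Compound 4, `Fc1cccc(F)c1Cc1cnc(Nc2ccc(CCOc3ccncc3)cc2)o1`, has not yet been measured. Its difference from compound 3 is ((pyridin-4-yl)oxy)methyl in place of (pyridin-4-yl)oxy on a saturated chain carbon bound to an aromatic carbon. Going by the values given here, no measured step changes this part of the molecule in the same way, so the expectation rests on where compound 3 already sits and on the fact that the change keeps the same ring and the same counts of donors and acceptors. Compound 4 is expected to remain at or near the limit, so the estimated step of a number no higher from compound 3 to compound 4 (the limit leaves the size open) is none beyond the scatter. For compound 4 the estimate in this assay is 100000 nM, with a range from 30000 nM to 300000 nM, and a limit rather than a number is the more likely report.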

Compound 4, half-maximal cytotoxic concentration: 11000 nM
Compound 4: middle estimate off by 9.1-fold (0.96 log units), on the high side; the whole stated range lies above it.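

The change from ((pyridin-4-yl)oxy)methyl to 2-((pyridin-4-yl)oxy)ethyl shows that this saturated chain carbon is not a silent place in this assay, and that one added chain carbon is enough to leave the limit: an at least 9.0-fold lower number from compound 3 to compound 4 (0.95 log units; beyond the scatter). Against the small cyano group, the longer ether chain brings no separation, as a 1.5-fold higher number from compound 2 to compound 4 (0.17 log units; within the scatter), while the other comparison at the same part of the molecule gives an at least 9.0-fold lower number from compound 1 to compound 4 (0.95 log units; beyond the scatter). The (pyridin-4-yl)oxy group thus appears in both compound 3 and compound 4 with different outcomes, and compound 1 and compound 3 remain limits of the assay and not numbers: the limit of > 100000 nM in this assay, at which 2 of the 4 values shown sit.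

From the compounds shown here alone, whether the lower number in this assay continues with a longer chain such as 3-((pyridin-4-yl)oxy)propyl, or changes when an amine takes the place of the ether oxygen, stays open. The step from compound 3 has one end at a limit, so its full size also stays open, and no cause for the change can be read from these compounds.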